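Oxime to acetyl on the anilide side of the series

A few compounds are considered here, and "the series" means these few. Any claim that something is new, unique, unknown or untested is made for them only; others in the source may bear on it.

Two members of the series have been run in a functional assay on PC-3 cells (Homo sapiens) for inhibition, read by sulforhodamine B assay, with a stated time of 48 h, tested at 10 uM (on this read-out higher numbers stand for more inhibition of growth at the one concentration tested and lower numbers for less inhibition of growth), so far. Compound 1 `C/C(=N\O)c1ccc(NC(=O)Cn2nc(-c3ccc(Cl)cc3)nc2N)cc1` carries a chlorine-bearing phenyl on the shared core and in this assay compound 1 gives 28.9%. Compound 2 `C/C(=N/O)c1ccc(NC(=O)Cn2nc(-c3ccccc3)nc2N)cc1` differs in the phenyl on the core and in this assay compound 2 gives 15.8%. Going by the values given here, compound 1 thus stands highest of the two numbers, with compound 2 lower by a step beyond the usual scatter; no single-change step between the two measured compounds exists, so the two values are all that can be said of that pair.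

Compound 3 `CC(=O)c1ccc(NC(=O)Cn2nc(-c3ccc(Cl)cc3)nc2N)cc1` keeps the chlorine-bearing phenyl of compound 1 and alters only the anilide side: a group of 3 heavy atoms (2 carbon, 1 oxygen; no ring) in place of a group of 4 heavy atoms (2 carbon, 1 nitrogen, 1 oxygen; no ring), on an aromatic carbon. Among the compounds with values here, no measured pair shows this change, so the size of its effect is unknown. The expectation is a step in this assay that stays within or only slightly beyond the scatter, more likely downward than upward, the estimated step being a number 6.9 percentage points lower from compound 1 to compound 3 (within the scatter). For compound 3 in this assay the estimate is 22%, within a range from 8% to 38%.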

Compound 3, percent growth inhibition at one concentration: 20.3%
For compound 3 the middle estimate is 1.7 percentage points above the measured one; the range from low to high includes it.
By their numbers in this assay, from the lowest: compounds 2, 3 and 1 (each within the scatter of the next, the first and the last beyond it).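

Going by these compounds alone, this is the first single-change step: with the chlorine-bearing phenyl held fixed, acetyl replaces the group of 4 heavy atoms on an aromatic carbon, para to a large group, and this assay shows a number 8.6 percentage points lower from compound 1 to compound 3 (within the scatter). The exchange therefore removes the 1 hydrogen-bond donor of the leaving group and takes the count from 2 hydrogen-bond acceptors to 1 hydrogen-bond acceptor, yet the read-out shows no change beyond the scatter, so this pair gives no sign that growth inhibition at this place depends on the leaving group rather than on acetyl. No measurement bears on what lies behind this small step.

Going by these compounds, it remains open whether the same exchange would read alike on the core carrying the phenyl without chlorine, since this single step comes from the chlorine-bearing pair alone. Also open, on these data alone, is how an amine, a carboxylic acid or a longer chain such as propionyl would read on this aromatic carbon, and whether any of them would move this assay beyond the scatter from compound 1.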